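The source may hold more compounds than are shown below. What is called first, only, known or untested is meant among the compounds shown, and "the series" means these compounds.

Measured so far in a functional assay on A549 cells (Homo sapiens) for inhibition, read by CCK-8 assay, with a stated time of 72 h, tested at 10 uM; on this read-out lower numbers stand for less inhibition of growth and higher numbers for more inhibition of growth at the one concentration tested:
compound 1, `CN(C)C(=O)c1cc2cnc(Nc3ccc(NC(=O)C4(C(=O)Nc5ccc(Cl)c(C(F)(F)F)c5)CC4)cc3)nc2n1C1CCCC1`: 88.1%
compound 2, `COC(=O)c1cccc(NC(=O)C2(C(=O)Nc3ccc(Nc4ncc5cc(C(=O)N(C)C)n(C6CCCC6)c5n4)cc3)CC2)c1`: 91%

Compound 2 gives the higher of the two numbers, but compound 1 lies within the scatter of it, so no order between them can be read. Within the data shown here, the only step available is a number 2.9 percentage points higher from compound 1 to compound 2 (within the scatter), an exchange of the whole aryl group on the same amide nitrogen that changed nothing beyond the scatter.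

Compound 3, `COc1cccc(NC(=O)C2(C(=O)Nc3ccc(Nc4ncc5cc(C(=O)N(C)C)n(C6CCCC6)c5n4)cc3)CC2)c1`, differs from compound 2 by methoxy in place of methoxycarbonyl on an aromatic carbon. This bears on the same aryl amide end of the molecule as the measured step, and that step stayed within the scatter, so no shift beyond the scatter is expected in this assay either; the estimated step is a number 4 percentage points lower from compound 2 to compound 3 (within the scatter). The expected result for compound 3 is 87%, with a range from 72% to 96%.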

Compound 3, percent growth inhibition at one concentration: 96%
Compound 3: middle estimate off by 9 percentage points, on the low side, and the stated range covers the measured number.
By their numbers in this assay, from the lowest: compounds 1, 2 and 3 (each within the scatter of the next).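

In this assay, methoxy in place of methoxycarbonyl on an aromatic carbon, meta to a large group, gives a number 5 percentage points higher from compound 2 to compound 3 (within the scatter) and so adds a second exchange at this aryl amide end that stays inside the scatter, this time a change of the substituent alone rather than of the whole aryl group. The exchange of 4-chloro-3-(trifluoromethyl)phenyl for 3-methoxyphenyl on the amide-type nitrogen gives a number 7.9 percentage points higher from compound 1 to compound 3 (within the scatter) and likewise allows no order among the three aryl ends. Nothing available explains these numbers.

On these data alone, whether an amine, a carboxylic acid or a longer alkoxy chain at this position would move the number beyond the scatter stays open. Readings at a single concentration also leave open whether compound 1, compound 2 and compound 3 would separate at lower concentrations.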